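Ring-nitrogen substituent change, cell-free plasma inhibition

A few compounds are considered here, and "the series" means these few. Any claim that something is new, unique, unknown or untested is made for them only; others in the source may bear on it.

Two compounds carry numbers in a functional assay on a cell-free system (plasma, Oryctolagus cuniculus) for inhibition, with stated times of 5 min, 1 min and 6 min; on this read-out lower numbers stand for stronger inhibition and higher numbers for weaker inhibition. Compound 1, `CCOC(=O)c1c(C)nc(-c2ccc(OCC(C)C)c(C#N)c2)n1O`, gives 16800 nM in this assay. Compound 2, `CCOC(=O)c1c(C)nc(-c2cccc(C#N)c2)n1C(C)C`, gives 9260 nM in this assay. Compound 2 holds the lowest of the two numbers, but the nearest, compound 1, lies within the scatter of it, so the two numbers show no order and both stand at weak inhibition. Within the data shown here, no step between compounds that differ in one place is available, as compound 1 and compound 2 differ in more than one place.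

Compound 3, `CCOC(=O)c1c(C)nc(-c2cccc(C#N)c2)n1OCCC(=O)O`, is not yet measured. It differs from compound 2 in one place: 2-carboxyethoxy in place of isopropyl on an aromatic nitrogen. Among the measured compounds shown here, the only comparison at hand, compound 1 against compound 2, shows no difference beyond the scatter, and both measured compounds sit in the same weak range, so the expectation for compound 3 is a step of a 1.3-fold higher number from compound 2 to compound 3 (0.11 log units; within the scatter) in this assay, which is no step beyond the scatter. Compound 3 is estimated at 12000 nM in this assay, with a range from 4000 nM to 40000 nM.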

Compound 3, half-maximal inhibitory concentration: > 30000 nM
Compound 3 was reported as a limit (the forecaster's own chance of this, stated with the estimate: 20%); at least 2.5-fold (0.39 log units) between middle value and limit.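

In this assay, among these compounds, a change at this position alone, 2-carboxyethoxy in place of isopropyl on an aromatic nitrogen, gives an at least 3.2-fold higher number from compound 2 to compound 3 (0.51 log units; beyond the scatter) and so provides the first reading that separates two compounds beyond the scatter. In this assay compound 3 gives > 30000 nM as a limit of the assay and not a number, so the direction of the step is read but its full size is not: the limit of > 30000 nM in this assay, at which 1 of the 3 values shown sits. The substituent on this nitrogen therefore bears on the read-out, at least for this pair, although the entering group differs from isopropyl at once in chain length, in its ether oxygen and in its carboxylic acid, and the step does not tell these apart.

As far as these compounds go, whether the step follows the carboxylic acid or the chain as a whole stays open; a plain propoxy group, the methyl ester of the same acid or a chain ending in an amine on this nitrogen would bear on that. Also open, from the compounds shown here alone, is whether any group here, such as a cyclopropyl or a methyl, gives stronger inhibition than isopropyl.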